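The source may hold more compounds than are shown below. What is called first, only, known or untested is meant among the compounds shown, and "the series" means these compounds.

Measured so far:
compound 1, `O=C(NCc1ccc(CNS(=O)(=O)c2ccccc2)cc1)c1cccc(F)c1`: 100 nM
compound 2, `Cc1ccc(S(=O)(=O)NCc2ccc(CNC(=O)c3c(Cl)cc(Cl)cc3Cl)cc2)cc1`: 10 nM

Both compounds were tested in an assay on MDA-MB-231 cells for binding affinity to C-X-C chemokine receptor type 4 (Homo sapiens), read by immunofluorescence and microscopy, with stated times of 10 min and 30 min; a higher number here means that more compound is needed for the effect, a lower number that less compound is needed. Compound 1 gives 100 nM there, the highest number of the two. Compound 2 gives 10 nM, a clearly lower number, and that gap lies well beyond the scatter of repeated measurements. Compound 1 and compound 2 differ at more than one place, so their two values alone do not show which change is responsible.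

The next compound, compound 3, `COc1cccc(C(=O)NCc2ccc(CNS(=O)(=O)c3ccccc3)cc2)c1`, has not yet been measured. It differs from compound 1 in one place only: methoxy in place of fluoro on an aromatic carbon. The fluoro leaves and a methoxy enters on an aromatic carbon of a six-membered aromatic ring of carbon only, meta to a large group, while the rest of the shared core is kept.

For the measured compounds named here, no measured pair shows what this swap does. The expectation is a small step in this assay, probably within the scatter, with no firm direction. Compound 3 is therefore estimated at 100 nM, within 40 nM to 250 nM. The expected step is no change at the digits printed from compound 1 to compound 3 (within the scatter), essentially none beyond the scatter.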

Compound 3, effective concentration (reported as EC, without a stated level of effect): > 1000 nM
Compound 3 gave a limit, no number; the forecaster's own chance of this, stated with the estimate: 5%; at least 10-fold (1.00 log units) between middle value and limit.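

In this assay, the meta carbon of this aromatic ring turns out not to be a place where any small group will do: methoxy in place of fluoro gives an at least 10-fold higher number from compound 1 to compound 3 (1.00 log units; beyond the scatter), so much more compound is needed for the effect. For the compounds shown here, this is the first change confined to one place, which the pair of compound 1 and compound 2 could not offer, so this step can be tied to a single swap. The step can be stated only as a minimum, because compound 3 rests on a limit and not on a number: the limit of > 1000 nM in this assay, at which 1 of the 3 values shown sits.

With only fluoro and methoxy compared at this carbon, the compounds shown do not tell whether the oxygen, the added carbon or the larger group as a whole accounts for the step, and a hydroxyl group or an amine at the same place could help to separate these possibilities. They also leave open whether the same swap would have a similar effect on the core of compound 2, which gives a lower number than compound 1 but differs from it in more than one place.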